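Swapping the aromatic amide cap for a benzothiazole

A few compounds are considered here, and "the series" means these few. Any claim that something is new, unique, unknown or untested is made for them only; others in the source may bear on it.

Compound 2 `O=C(CCCCCCNC(=O)C(O)(O)C(F)(F)F)Nc1ccc(Cl)cc1` is the compound with the lowest number among the two measured in an assay on isolated protein for inhibition of protein deacetylase HDAC6 (Homo sapiens), read by chemiluminescence, with a stated time of 3 h (on this read-out higher numbers stand for weaker inhibition and lower numbers for stronger inhibition), where compound 2 gives 260000 nM. Its nearest neighbour is compound 1 `COc1ccc(NC(=O)CCCCCCNC(=O)C(O)(O)C(F)(F)F)cc1`, which in this assay gives 440000 nM; the two differ by a 1.7-fold lower number from compound 1 to compound 2 (0.23 log units; within the scatter), so they cannot be told apart. Compound 3 `O=C(CCCCCCNC(=O)C(O)(O)C(F)(F)F)Nc1nc2ccccc2s1` has not yet been measured in this assay. It differs from compound 2 by 1,3-benzothiazol-2-yl in place of 4-chlorophenyl on an amide-type nitrogen. Going by the values given here, the only measured step, a 1.7-fold lower number from compound 1 to compound 2 (0.23 log units; within the scatter), concerns a change of a small group on the aromatic ring and lies within the scatter, whereas the step to compound 3 replaces the whole aromatic cap with a ring system that carries two hydrogen-bond acceptors. Among the compounds with values here, no measured pair covers such an exchange, so the direction cannot be read from the data. The expected outcome is therefore a step of a 1.3-fold lower number from compound 2 to compound 3 (0.11 log units; within the scatter), not beyond the scatter. Compound 3 is estimated to give 200000 nM in this assay, with a range from 60000 nM to 900000 nM.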

Compound 3, half-maximal inhibitory concentration: 82000 nM
The estimate for compound 3 lay 2.4-fold (0.39 log units) above the measured number; low and high end bracket the measured number.
By their numbers in this assay, from the lowest: compound 3; then compounds 2 and 1 (each within the scatter of the next).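

Going by these compounds alone, compound 3 is the first change at this position, the amide-type nitrogen, to move the number beyond the scatter: putting 1,3-benzothiazol-2-yl in place of 4-chlorophenyl in this assay gives a 3.2-fold lower number from compound 2 to compound 3 (0.50 log units; beyond the scatter), and putting it in place of 4-methoxyphenyl gives a 5.4-fold lower number from compound 1 to compound 3 (0.73 log units; beyond the scatter). Within the data shown here, the earlier pair showed only that exchanging a small group on the phenyl ring left the two compounds indistinguishable, whereas exchanging the whole aromatic group does register, although both new steps are modest and compound 3, the strongest inhibitor of the three, still gives 82000 nM. Nothing measured here speaks to the reason for this step.

The compounds shown leave open whether the gain comes from the larger two-ring group as such or from the nitrogen and sulfur it carries, a question on which a naphthyl or a 1,3-benzoxazol-2-yl group at the same place would bear. From the compounds shown here alone, it also remains open whether a longer chain in the shared core would add to this step or cancel it.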